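Chain extension on a second core: expected cytotoxicity of compound 4

A few compounds are considered here, and "the series" means these few. Any claim that something is new, unique, unknown or untested is made for them only; others in the source may bear on it.

Of the compounds shown here, three have been measured in a functional assay on DLD-1 cells (Homo sapiens) for cytotoxicity; on this read-out lower numbers stand for stronger inhibition and higher numbers for weaker inhibition. Compound 1 `N#C/N=C1\N(CCCCCCOc2ccc(Cl)cc2)C(=O)C(c2ccccc2)N1c1ccncc1` gives 37 nM. Compound 2 `N#C/N=C1\N(CCCCCCCOc2ccc(Cl)cc2)C(=O)C(c2ccccc2)N1c1ccncc1`, which carries (4-chlorophenoxy)methyl in place of 4-chlorophenoxy on a saturated chain carbon, six bonds along the chain from an amide-type nitrogen in a ring, gives 290 nM; the step of a 7.8-fold higher number from compound 1 to compound 2 (0.89 log units; beyond the scatter) is recorded. Compound 3 `N#C/N=C1\N(CCCCCCOc2ccc(Cl)cc2)C(=O)CCN1c1ccncc1` rests on a different core; how its core differs from that of compound 1 is not broken down here. In this assay compound 3 gives 565 nM, the highest of the three numbers, though its gap to compound 2 lies within the usual scatter.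

Compound 4 `N#C/N=C1\N(CCCCCCCOc2ccc(Cl)cc2)C(=O)CCN1c1ccncc1` has not yet been measured. Relative to compound 3 it carries (4-chlorophenoxy)methyl in place of 4-chlorophenoxy on a saturated chain carbon, six bonds along the chain from an amide-type nitrogen in a ring, the same change that turns compound 1 into compound 2, made at the same place. Because a 7.8-fold higher number from compound 1 to compound 2 (0.89 log units; beyond the scatter) was seen on the first core, a step of similar direction is expected on the second core, with the step of a 6.2-fold higher number from compound 3 to compound 4 (0.79 log units; beyond the scatter) estimated from that single precedent alone. On this basis compound 4 is expected to give about 3500 nM, with a plausible range from 900 nM to 14000 nM.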

Compound 4, half-maximal inhibitory concentration: 3200 nM
Compound 4: middle estimate off by 1.1-fold (0.04 log units), on the high side, within the range that was stated.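

In this assay, putting (4-chlorophenoxy)methyl in place of 4-chlorophenoxy on the core of compound 3 gave a 5.7-fold higher number from compound 3 to compound 4 (0.75 log units; beyond the scatter), and this step agrees with the one seen on the core of compound 1: the same change on two cores in this assay, a 7.8-fold higher number (0.89 log units; beyond the scatter) from compound 1 to compound 2 and a 5.7-fold higher number (0.75 log units; beyond the scatter) from compound 3 to compound 4, 1.4-fold (0.14 log units) apart, within the scatter of two such steps Within this series, the change therefore carried over from one core to the other in both direction and size, so the step seen on the first core described the second well. For the compounds shown here, this rests on only two matched pairs, however, and it does not show that the same step would appear on a further core or in another read-out, nor does it explain why the numbers rise.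

From the compounds shown here alone, it remains open whether a shorter chain or a longer chain would follow the same course on both cores. It is also unknown how either core would respond if an amine or a carboxylic acid stood in place of 4-chlorophenoxy on the chain.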